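This account rests on a few compounds, and the source may have more. Where it says the series, first, only, none or still open, it means among the compounds named here.

Within the data shown here, in a functional assay on MGC-803 cells (Homo sapiens) for inhibition, read by MTT assay, with a stated time of 48 h (on this read-out higher numbers stand for weaker inhibition and lower numbers for stronger inhibition), compound 1 (`C/C=C/C(=O)N(Cc1ccc(OC)c(OC)c1)c1cc(OC)c(OC)c(OC)c1`) gives 20100 nM, the highest of the three numbers measured so far and the weakest inhibition among them. Compound 2 (`C/C=C/C=C/C(=O)N(Cc1ccc(OC)c(O)c1)c1cc(OC)c(OC)c(OC)c1`) gives 140 nM, and compound 3 (`CCC/C=C/C(=O)N(Cc1ccc(OC)c(O)c1)c1cc(OC)c(OC)c(OC)c1`) gives 70 nM. Neither is a single-place neighbour of compound 1, so their much lower numbers cannot be assigned to any one change. Among the measured compounds shown here, the only single-place step measured, a 2.0-fold lower number from compound 2 to compound 3 (0.30 log units; within the scatter), lies in the chain and within the scatter, and it says nothing about the aromatic carbon in question here.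

Compound 4 (`C/C=C/C(=O)N(Cc1ccc(OC)c(Cl)c1)c1cc(OC)c(OC)c(OC)c1`) has chloro in place of methoxy on an aromatic carbon, ortho to a methoxy group: chloro in place of methoxy on an aromatic carbon. For the measured compounds named here, no measured step covers this exchange, so no step beyond the scatter is expected in this assay. The expected step is a 1.8-fold lower number from compound 1 to compound 4 (0.26 log units; within the scatter), a slight move to a lower number at most. Compound 4 is estimated at 11000 nM, with an expected range of 3000 nM to 30000 nM.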

Compound 4, half-maximal inhibitory concentration: 7100 nM
Compound 4: middle estimate off by 1.5-fold (0.19 log units), on the high side; the measured number falls inside the stated range.
By their numbers in this assay, from the lowest: compounds 3 and 2 (each within the scatter of the next); then compound 4; then compound 1.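

In this assay, the exchange on this aromatic carbon now has a measured single-place step (a move a 2.8-fold lower number from compound 1 to compound 4 (0.45 log units; beyond the scatter)), and it is modest. The methoxy group is therefore not required at this position for the inhibition seen with compound 1: chloro, with one heavy atom and no hydrogen-bond acceptor, goes with a lower number rather than a higher one. Nothing measured on these compounds accounts for the step, so its cause remains unexplained.

On these data alone, whether the trend would extend to fluoro, bromo, methyl or an amine on this carbon remains open. Compounds 2 and 3 carry hydroxy on this carbon but also differ from compound 1 in the chain, so the part played by hydroxy alone also remains unresolved.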